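The compounds below may be only part of what the source reports. "The series", "measured", "known", "first", "only" and "open" are said of these compounds alone.

Compounds measured so far:
compound 1 `Cc1cc(C(=O)O)ccc1C(C)N1CCC[C@H](O[C@H](CO)c2cc(Cl)cc(Cl)c2)[C@@H]1c1ccccc1`, with the entry "nd" (no result reported) (no result reported)
compound 2 `Cc1cc(C(=O)O)ccc1CN1CCC[C@H](O[C@H](CO)c2cccc(Cl)c2)[C@@H]1c1ccccc1`, giving 93000 nM

The study was read out in an assay on isolated protein for activation of cGMP-dependent protein kinase 1 (Homo sapiens), read by ADP-Glo, with stated times of 30 min and 2 h; on this read-out higher numbers stand for an effect only at larger amounts of compound and lower numbers for an effect already at smaller amounts. For compound 1 no number stands on record in this assay, its entry being "nd" (no result reported), so compound 1 cannot be placed on the scale at all. Among the measured compounds shown here, the only number in this assay belongs to compound 2, which gives 93000 nM, an effect seen only at a very large amount of compound; no step between compound 1 and compound 2 is recorded, so their two entries are simply what they are.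

The step under consideration leads from compound 1 to compound 3 `O=C(O)C12CC(CN3CCC[C@H](O[C@H](CO)c4cc(Cl)cc(Cl)c4)[C@@H]3c3ccccc3)(C1)C2`. The change is a group of 9 heavy atoms (7 carbon, 2 oxygen; 2 four-membered non-aromatic rings of carbon only) in place of a group of 12 heavy atoms (10 carbon, 2 oxygen; one six-membered aromatic ring of carbon only), on an amine nitrogen in a ring. For the measured compounds named here, with no number for compound 1 and no recorded step involving compound 3, the direction of this change cannot be inferred from the data; the size expected in this assay is therefore none beyond the scatter in either direction, stated only as a default. Compound 3 is accordingly expected to give about 60000 nM, with a range from 10000 nM to 300000 nM, resting on the weak value of compound 2 as the sole anchor.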

Compound 3, half-maximal effective concentration: > 200000 nM
Compound 3: no number, only a limit; the forecaster's own chance of this, stated with the estimate: 35%; middle value at least 3.3-fold (0.52 log units) from the limit.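

In this assay compound 3 gives > 200000 nM, which is a limit and not a number. Among the compounds shown here, since compound 1 has no number to set against it, no step from compound 1 to compound 3 can be read. The compounds shown leave open how the group on the amine nitrogen in a ring bears on this read-out.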